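From Trifluoromethyl to Chloro in Compound 3

The compounds below may be only part of what the source reports. "The series", "measured", "known", "first", "only" and "open" are said of these compounds alone.

Of the compounds shown here, three have so far been tested in an ADME assay on Vero cells (Chlorocebus sabaeus) for cytotoxicity, read by resazurin assay, with a stated time of 72 h; on this read-out higher numbers stand for weaker inhibition and lower numbers for stronger inhibition. Compound 1 `Cc1ccc(C(=O)CCN2CCN(c3ccc(Cl)cc3)CC2)cc1` gives 184000 nM, compound 2 `COc1ccc(C(=O)CCN2CCN(c3ccc(F)cc3)CC2)cc1` gives 55000 nM, and compound 3 `COc1ccc(C(=O)CCN2CCN(c3ccc(C(F)(F)F)cc3)CC2)cc1` gives 135000 nM. The numbers of compound 3 and compound 1 lie within the scatter of each other, so compound 3 shares the upper part of this small set, and only compound 2 stands clearly apart.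

Compound 4 `COc1ccc(C(=O)CCN2CCN(c3ccc(Cl)cc3)CC2)cc1` keeps the core of compound 3 and changes a single group: chloro in place of trifluoromethyl on an aromatic carbon. One measured step involves a swap of this kind, trifluoromethyl in place of fluoro on an aromatic carbon, and it is modest: a 2.5-fold higher number from compound 2 to compound 3 (0.39 log units; beyond the scatter). Chloro itself has been measured only in compound 1, which also differs elsewhere in the molecule and gives 184000 nM. With this little evidence, the value of compound 4 is expected to stay near that of compound 3, and no step beyond the scatter is expected. The estimated change is a 1.2-fold lower number from compound 3 to compound 4 (0.07 log units; within the scatter). For compound 4 the estimated value is 115000 nM, with an expected range from 55000 nM to 220000 nM.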

Compound 4, half-maximal inhibitory concentration: 300000 nM
Estimate against measurement, compound 4: 2.6-fold (0.42 log units) below, and the stated range ends below it.
By their numbers in this assay, from the lowest: compound 2; then compounds 3, 1 and 4 (each within the scatter of the next, the first and the last beyond it).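

The group on this aromatic carbon, para to a large group, now has three measured members on the methoxy-bearing core, and in this assay the choice among them matters: chloro in place of trifluoromethyl gives a 2.2-fold higher number from compound 3 to compound 4 (0.35 log units; beyond the scatter), and chloro in place of fluoro gives a 5.5-fold higher number from compound 2 to compound 4 (0.74 log units; beyond the scatter). Together with the earlier step from fluoro to trifluoromethyl, this places the three compounds in the order compound 2, compound 3, compound 4, from strongest to weakest inhibition, with each step beyond the scatter, so a single chlorine atom and a trifluoromethyl group are not interchangeable here. With chloro held fixed, methoxy in place of methyl gives a 1.6-fold higher number from compound 1 to compound 4 (0.21 log units; within the scatter), which lies within the scatter, so this one pair shows no measurable effect of that swap.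

No measurement among these compounds explains why the three groups differ. Going by these compounds, it remains open where a bromo, a nitrile or an amine at the same position would fall, and whether methoxy and methyl would also match each other with fluoro or trifluoromethyl in place of chloro.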